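Chloro for fluoro in the 2-fluorophenyl compound

A few compounds are considered here, and "the series" means these few. Any claim that something is new, unique, unknown or untested is made for them only; others in the source may bear on it.

compound 1 `COc1cc(C(=O)c2cn(-c3cccc(C)c3)cc2-c2ccccc2Cl)cc(OC)c1OC`: 420 nM
compound 2 `COc1cc(C(=O)c2cn(-c3ccc(C)cc3)cc2-c2ccccc2F)cc(OC)c1OC`: 44 nM

In a functional assay on MCF7 cells (Homo sapiens) for cytotoxicity, read by MTT assay, with a stated time of 96 h (on this read-out higher numbers stand for weaker inhibition and lower numbers for stronger inhibition), compound 2 gives 44 nM, the lower of the two numbers. Compound 1 gives 420 nM. The gap between these two numbers lies beyond the scatter. Compound 3 `COc1cc(C(=O)c2cn(-c3ccc(C)cc3)cc2-c2ccccc2Cl)cc(OC)c1OC` follows from compound 2 by the change (chloro in place of fluoro on an aromatic carbon), chloro in place of fluoro on an aromatic carbon, ortho to a large group. Among the compounds with values here, no measured pair isolates this change. Compound 1, at 420 nM, carries the same 2-chlorophenyl group but also differs elsewhere, so only a moderate rise is expected. The expected step is a 2.3-fold higher number from compound 2 to compound 3 (0.36 log units; beyond the scatter), toward weaker inhibition and probably just beyond the scatter. The estimate for compound 3 is 100 nM, within a range of 35 nM to 300 nM.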

Compound 3, half-maximal inhibitory concentration: 180 nM
Estimate against measurement, compound 3: 1.8-fold (0.26 log units) below; low and high end bracket the measured number.
By their numbers in this assay, from the lowest: compound 2; then compound 3; then compound 1.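

In this assay, the change from 2-fluorophenyl to 2-chlorophenyl is now isolated and costs activity at this position (a 4.1-fold higher number from compound 2 to compound 3 (0.61 log units; beyond the scatter)). With the 2-chlorophenyl group held constant, 4-methylphenyl in place of 3-methylphenyl on an aromatic nitrogen also gives a separate gain (a 2.3-fold lower number from compound 1 to compound 3 (0.37 log units; beyond the scatter)), so the gap between compound 1 and compound 2 contains two single changes. Nothing available explains either step.

Still open, on these data alone, is how a methoxy group or an amine in place of the fluoro would read. Also open, as far as these compounds go, is whether the 2-fluorophenyl advantage holds alongside 3-methylphenyl.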